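A few compounds are considered here, and "the series" means these few. Any claim that something is new, unique, unknown or untested is made for them only; others in the source may bear on it.

Series of aryl-substituted diamine rings examined in a functional assay on HEK293 cells for agonist activity at Neuronal acetylcholine receptor; alpha4/beta2 (Homo sapiens), read by FLIPR and calcium flux; on this read-out higher numbers stand for an effect only at larger amounts of compound and lower numbers for an effect already at smaller amounts. Compound 1 `c1cncc(N2CCCNCCC2)c1` gives 36.3 nM in this assay, the lowest of the three numbers at hand. Compound 2 `C/C=C\Oc1cncc(N2CCCNCC2)c1` gives 2090 nM, and compound 3 `COc1cc(N2CCNCC2)cnc1Br` gives 17000 nM; both sit well beyond the scatter above compound 1, the gap being larger for compound 3. No pair among these three differs in one place only, so no single-point step can be read off from measured compounds.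

Compound 4 `COc1cncc(N2CCCNCCC2)c1` is compound 1 with methoxy in place of hydrogen on an aromatic carbon. Going by the values given here, both compounds that carry an ether on the aromatic ring, compound 2 and compound 3, show higher numbers than compound 1, but each of them also differs in the ring bound to the aromatic core, so no clean precedent exists for adding a methoxy alone. A moderate rise is therefore expected for the step of a 3.0-fold higher number from compound 1 to compound 4 (0.48 log units; beyond the scatter), short of the distance seen to compound 2. Compound 4 is estimated at 110 nM, with a range from 30 nM to 450 nM.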

Compound 4, half-maximal effective concentration: 120 nM
The estimate for compound 4 lay 1.1-fold (0.04 log units) below the measured number; low and high end bracket the measured number.
By their numbers in this assay, from the lowest: compound 1; then compound 4; then compound 2; then compound 3.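

In this assay, going by these compounds alone, methoxy in place of hydrogen on an aromatic carbon, two atoms from the ring nitrogen, gives a 3.3-fold higher number from compound 1 to compound 4 (0.52 log units; beyond the scatter), the first step that can be read at a single place. The step is modest, and with this substituent on the core of compound 1, compound 4 still gives 120 nM, so this position tolerates an ether while the number rises. Nothing at hand bears on what lies behind the rise.

As far as these compounds go, whether the rise follows from the oxygen or from the attached methyl stays open; a hydroxyl, a fluorine or an ethoxy at the same place would begin to separate these. Also open, from the compounds shown here alone, is whether methoxy gives a step of similar size with a different ring bound to the aromatic core.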